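Adding a second chloro to the hydroxyphenyl ring of compound 3

The source may report more compounds than this note shows. Statements on the series, on what has been measured and on what is new or still open speak of the compounds shown alone.

Of the compounds shown here, three sharing one core have been measured in a functional assay on A549 cells (Homo sapiens) for inhibition, read by MTT assay, with a stated time of 48 h; on this read-out lower numbers stand for stronger inhibition and higher numbers for weaker inhibition. Compound 1 `C/C(=N\NC(=O)c1cc(-c2ccccc2)nn1Cc1ccc(C(C)(C)C)cc1)c1cc(Cl)cc(Cl)c1O` gives 3170 nM. Among the compounds with values here, compound 2 `C/C(=N\NC(=O)c1cc(-c2ccc(Cl)cc2)nn1Cc1ccc(C(C)(C)C)cc1)c1cc(Cl)cc(Cl)c1O` gives 7900 nM, and the step of a 2.5-fold higher number from compound 1 to compound 2 (0.40 log units; beyond the scatter) is the only single change measured so far. Compound 3 `COc1ccc(-c2cc(C(=O)N/N=C(\C)c3cc(Cl)ccc3O)n(Cc3ccc(C(C)(C)C)cc3)n2)cc1` gives 9620 nM, the highest of the three numbers; its gap to compound 2 lies within the scatter, while its gap to compound 1 lies beyond it.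

Compound 4 `COc1ccc(-c2cc(C(=O)N/N=C(\C)c3cc(Cl)cc(Cl)c3O)n(Cc3ccc(C(C)(C)C)cc3)n2)cc1` differs from compound 3 by chloro in place of hydrogen on an aromatic carbon. Within the data shown here, no measured step changes that same ring, so none bears on it directly. Among the measured compounds shown here, the one measured step, a 2.5-fold higher number from compound 1 to compound 2 (0.40 log units; beyond the scatter), placed a chloro on a different ring and gave a modest rise; it shows only that a single chloro can move the number by a modest amount. Compounds 1 and 2 both carry the 3,5-dichloro-2-hydroxyphenyl group and span both lower and comparable numbers to compound 3, so no direction is secured.

Compound 4 is therefore expected to give about 7000 nM, within a range of 2500 nM to 20000 nM in this assay. The expected step from compound 3 is a 1.4-fold lower number from compound 3 to compound 4 (0.14 log units; within the scatter), which is judged to be within or close to the usual scatter.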

Compound 4, half-maximal inhibitory concentration: 2080 nM
Compound 4: the middle estimate sits 3.4-fold (0.53 log units) above what was measured, outside the stated range (below it).
By their numbers in this assay, from the lowest: compounds 4 and 1 (each within the scatter of the next); then compounds 2 and 3 (each within the scatter of the next).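

In this assay, this position responds clearly on the core of compound 3: going from 5-chloro-2-hydroxyphenyl to 3,5-dichloro-2-hydroxyphenyl, with the new chloro ortho to the hydroxy group, gives a 4.6-fold lower number from compound 3 to compound 4 (0.67 log units; beyond the scatter). With the dichloro group held constant, the substituent on the other aromatic ring also matters, since methoxy in place of chloro gives a 3.8-fold lower number from compound 2 to compound 4 (0.58 log units; beyond the scatter), whereas methoxy in place of hydrogen gives a 1.5-fold lower number from compound 1 to compound 4 (0.18 log units; within the scatter), which leaves these two compounds unseparated. Chloro in place of hydrogen thus has no single direction in this series, and the two measured cases point opposite ways at different places on different cores: the same change on two cores in this assay, a 2.5-fold higher number (0.40 log units; beyond the scatter) from compound 1 to compound 2 and a 4.6-fold lower number (0.67 log units; beyond the scatter) from compound 3 to compound 4, 12-fold (1.06 log units) apart, beyond the scatter of two such steps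

Only hydrogen and chloro stand at this position among the compounds shown, so it remains open whether a bromo, a methyl or an amine there would give a number close to that of compound 4. Also open, going by these compounds, is how large the same hydrogen-to-chloro step would be on the core of compound 1.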